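This account rests on a few compounds, and the source may have more. Where it says the series, first, only, none or still open, it means among the compounds named here.

Of the compounds shown here, three of one series have been tested in a functional assay on the whole organism with Rattus norvegicus as the target, at a dose of 20 mg/kg by the intraperitoneal route; a lower number here means less inhibition, a higher number more inhibition at the dose given (going by the name of the read-out). Compound 1 `Nc1nc(N)nc(-c2ccccc2Br)n1` gives 26% in this assay. Compound 3 `Nc1nc(N)nc(-c2cccc(Cl)c2)n1` gives 100% in this assay. Compound 2 `Nc1nc(N)nc(-c2cc(F)ccc2Cl)n1` gives 78% in this assay, which places it second highest of the three numbers: its nearest neighbour is compound 3, whose number lies higher by a margin beyond the scatter, and the furthest is compound 1, whose number lies lower by a margin well beyond the scatter.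

The step followed here leads from compound 2 to the untested compound 4 `Nc1nc(N)nc(-c2cc(C(F)(F)F)ccc2Cl)n1`. The change is trifluoromethyl in place of fluoro on an aromatic carbon. The trifluoromethyl group enters on an aromatic carbon of a six-membered aromatic ring of carbon only, para to a chloro group, where the fluoro group stood before. Within the data shown here, no measured pair differs in just this way, so no measured step can be drawn on for its size.

Given that compound 2 already gives 78%, the step from compound 2 to compound 4 is expected to be small, with a number 4 percentage points higher from compound 2 to compound 4 (within the scatter) lying within the usual scatter and leaning, if anywhere, slightly upward. Compound 4 is therefore estimated to give about 82% in this assay, with a range from 55% to 100%.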

Compound 4, a percentage reported as inhibition, in the whole organism at one dose (the size of the read-out at that dose, not a potency): 51%
For compound 4 the middle estimate is 31 percentage points above the measured one, outside the stated range (below it).
By their numbers in this assay, from the lowest: compound 1; then compound 4; then compound 2; then compound 3.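

In this assay, among these compounds, placing trifluoromethyl in place of fluoro on this aromatic carbon, para to a chloro group, gives a number 27 percentage points lower from compound 2 to compound 4 (beyond the scatter) and is the first direct sign that the read-out responds to what stands at this position. The substituent here is not interchangeable: with fluoro replaced by trifluoromethyl, which has more heavy atoms and likewise carries no hydrogen-bond donors or acceptors and no net charge, part of the inhibition seen with compound 2 is lost, although compound 4 still shows a measurable effect at the dose given. Nothing available explains this loss, so the step stands as an observation only.

With one matched pair, the compounds shown leave open whether the inhibition falls steadily with the number of heavy atoms at this position or whether trifluoromethyl is a special case. A methyl group, a methoxy group, a nitrile or an amine on the same aromatic carbon could separate these readings, while the one dose leaves open whether the gap between compound 2 and compound 4 would persist at other doses.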